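A few compounds are considered here, and "the series" means these few. Any claim that something is new, unique, unknown or untested is made for them only; others in the source may bear on it.

Compound 1 `Cc1csc2cc([C@H](C)Nc3ncnc(N)c3C#N)c(Cc3cccc(CN4CCC4)c3)c(=O)n12`: 1.1 h
Compound 2 `Cc1csc2cc([C@H](C)Nc3ncnc(N)c3C#N)c(-c3cccc(CN4CCC(CN(C)Cc5ccccn5)CC4)c3)c(=O)n12`: 10.9 h
Compound 3 `Cc1csc2cc([C@H](C)Nc3ncnc(N)c3C#N)c(Cc3cccc(CN)c3)c(=O)n12`: 1.6 h

In an ADME assay on the whole organism (lung, Rattus norvegicus) for metabolic stability, read by LC-MS (on this read-out higher numbers stand for a longer-lived compound and lower numbers for a shorter-lived compound), compound 3 gives 1.6 h, second highest of the three numbers, within the scatter of compound 1 and clearly short of compound 2. Compound 4 `Cc1csc2cc([C@H](C)Nc3ncnc(N)c3C#N)c(-c3ccccc3)c(=O)n12` is still unmeasured. It differs from compound 3 as follows: phenyl in place of 3-(aminomethyl)benzyl on an aromatic carbon. Among the compounds with values here, the one measured step, a 1.5-fold higher number from compound 1 to compound 3 (0.16 log units; within the scatter), lies within the scatter, but it changes only the end of the side group, so it is a weak guide here. A small drop is expected, with no step beyond the scatter. The estimate means a 1.6-fold lower number from compound 3 to compound 4 (0.20 log units; within the scatter), which is expected to stay within the scatter. For compound 4 the estimated half-life is 1 h, with an expected range of 0.35 h to 2.8 h.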

Compound 4, half-life: < 0.1 h
Compound 4 was reported as a limit; the forecaster's own chance of this, stated with the estimate: 5%; at least 10-fold (1.00 log units) between middle value and limit.
By their numbers in this assay, from the lowest: compounds 1 and 3 (each within the scatter of the next); then compound 2. At a limit, below all of these: compound 4.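

Compound 4 gives < 0.1 h in this assay, a limit of the assay and not a number. On this aromatic carbon, replacing the whole side group with phenyl brings an at least 16-fold lower number from compound 3 to compound 4 (1.20 log units; beyond the scatter), whereas changing only the end of that side group brought a 1.5-fold higher number from compound 1 to compound 3 (0.16 log units; within the scatter). The larger step therefore has a known minimum size but no known full size: the limit of < 0.1 h in this assay, at which 1 of the 4 values shown sits.

The change removes the benzyl carbon and the aminomethyl group together, and the compounds shown do not separate them. A plain benzyl group, or a phenyl carrying aminomethyl directly, would show which part accounts for the step.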